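This account rests on a few compounds, and the source may have more. Where it says the series, first, only, none or still open, it means among the compounds named here.

Of the compounds shown here, three that share one core have so far been tested in a functional assay on HEK293 cells for agonist activity at Vasopressin V2 receptor (Homo sapiens), read by a luciferase reporter and cAMP accumulation; on this read-out lower numbers stand for an effect already at smaller amounts and higher numbers for an effect only at larger amounts of compound. Compound 1 `O=C(NCc1ccc(C(=O)N2CCCCc3ccccc32)c(Cl)c1)Nc1c(F)cccc1F` gives 40 nM. Compound 2 `Cc1cc(C(=O)N2CCCCc3ccccc32)cc(C)c1CNC(=O)Nc1c(F)cccc1F` gives 82 nM. Compound 3 `Cc1cc(C(=O)N2CCCCc3ccccc32)ccc1CNC(=O)Nc1ccccc1F` gives 30 nM. Compound 3 has the lowest of the three numbers; its gap to compound 1 lies within the usual scatter of repeated measurements, so these two cannot be told apart, whereas compound 2 lies beyond the scatter and needs a larger amount of compound for its effect. No two of the measured compounds differ in a single place, so no single structural step can be read off among them.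

Compound 4 `Cc1cc(C(=O)N2CCCCc3ccccc32)ccc1CNC(=O)NCC(N)=O` has not yet been measured. It differs from compound 3 in one place: carbamoylmethyl in place of 2-fluorophenyl on an amide-type nitrogen. An aromatic ring thus gives way to a chain with no ring, on the amide-type nitrogen whose other neighbour is a carbonyl carbon. Every measured compound carries an aromatic ring on that nitrogen, so nothing here shows what removing it does. The change is nevertheless a large one, and the expected step in this assay is a 10-fold higher number from compound 3 to compound 4 (1.00 log units; beyond the scatter), upward and beyond the scatter. Compound 4 is therefore expected to give about 300 nM, within a range from 60 nM to 3000 nM.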

Compound 4, half-maximal effective concentration: 210 nM
Beside the measured number, compound 4's estimate is 1.4-fold (0.15 log units) above it, and the stated range covers the measured number.
By their numbers in this assay, from the lowest: compounds 3 and 1 (each within the scatter of the next); then compound 2; then compound 4.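

Among the compounds shown here, every earlier compound carries an aromatic ring on the amide-type nitrogen, so this is the first view of that position without one: in this assay, putting carbamoylmethyl in place of 2-fluorophenyl gives a 7.0-fold higher number from compound 3 to compound 4 (0.85 log units; beyond the scatter). The change costs a clear amount of potency but does not abolish the effect, as compound 4, with no ring at that position, still gives 210 nM. Nothing in the data shown speaks to why the number moves this way.

This single change removes an aromatic ring and brings in a chain with a hydrogen-bond donor and a hydrogen-bond acceptor, so the compounds shown cannot separate the loss of the ring from the arrival of the carbamoylmethyl group; a plain ethyl group, a benzyl group or a carboxymethyl group on that nitrogen would be needed to pull those effects apart. Going by these compounds, it also remains open whether the same replacement would have a step of similar size on the core of compound 1 or the core of compound 2.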